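A few compounds are considered here, and "the series" means these few. Any claim that something is new, unique, unknown or untested is made for them only; others in the source may bear on it.

Compound 1 `O=C1Nc2ccccc2/C1=N/NC(=S)N1CCN(c2ccccc2)CC1` is the starting point: in a functional assay on MCF7 cells (Homo sapiens) for inhibition, read by MTT assay, with a stated time of 72 h (a lower number here means a stronger inhibitor, a higher number a weaker inhibitor), compound 1 gives 24900 nM. Compound 2 `COc1ccc2c(c1)/C(=N/NC(=S)N1CCN(c3ccccc3)CC1)C(=O)N2` carries one change, (methoxy in place of hydrogen on an aromatic carbon), and in this assay compound 2 gives 14400 nM, a step of a 1.7-fold lower number from compound 1 to compound 2 (0.24 log units; within the scatter). Compound 3 `O=C1Nc2ccc(Cl)cc2/C1=N/NC(=S)N1CCN(c2ccccc2)CC1` differs from compound 1 in its core by chloro in place of hydrogen on an aromatic carbon; in this assay compound 3 gives 10400 nM, a step of a 2.4-fold lower number from compound 1 to compound 3 (0.38 log units; beyond the scatter). Compound 4 `COc1ccc(N2CCN(C(=S)N/N=C3\C(=O)Nc4ccc(Cl)cc43)CC2)cc1`, not yet measured, arises from compound 3 by methoxy in place of hydrogen on an aromatic carbon. This is the same kind of change as that from compound 1 to compound 2, but not the same: there the methoxy sits on a ring that is part of a fused system, meta and para to a fused ring, while here it sits on a six-membered ring of carbon only, para to a large group. Because the earlier step of a 1.7-fold lower number from compound 1 to compound 2 (0.24 log units; within the scatter) stayed within the scatter, a small step is expected here as well, a 1.3-fold lower number from compound 3 to compound 4 (0.11 log units; within the scatter). Compound 4 is therefore estimated at 8000 nM, with a range from 4000 nM to 16000 nM.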

Compound 4, half-maximal inhibitory concentration: 13800 nM
Beside the measured number, compound 4's estimate is 1.7-fold (0.24 log units) below it; the measured number falls inside the stated range.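

Putting methoxy on the phenyl ring keeps the numbers in this assay within the usual scatter (a 1.3-fold higher number from compound 3 to compound 4 (0.12 log units; within the scatter)). The two methoxy steps also cannot be told apart, even though they are printed with opposite directions: the same change on two cores in this assay, a 1.7-fold lower number (0.24 log units; within the scatter) from compound 1 to compound 2 and a 1.3-fold higher number (0.12 log units; within the scatter) from compound 3 to compound 4, 2.3-fold (0.36 log units) apart, within the scatter of two such steps. This fits a change that does little on either core, but it does not show that an effect carries from one core to the other, as neither step can be separated from the scatter and the methoxy sits on a different ring in each pair.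

Still open, on these data alone, is whether another group on that phenyl ring, such as an amine or a carboxylic acid, would give a step beyond the scatter.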